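The compounds below may be only part of what the source reports. "The series", "measured", "known", "first", "only" and "open" are said of these compounds alone.

Compound 1 `CS/C(=N\C(=O)c1cc(-c2ccccc2)nc2ccccc12)NC(=O)c1cc(-c2ccccc2)nc2ccccc12` is the stronger of the two measured compounds in this study. In an ADME assay on MCF-10A cells (Homo sapiens) for cytotoxicity, read by MTT assay, with a stated time of 72 h (on this read-out higher numbers stand for weaker inhibition of growth and lower numbers for stronger inhibition of growth), compound 1 gives 40 nM, the lowest of the two numbers at hand. Among the measured compounds shown here, the only other measured compound, compound 2 `O=C(/N=C(/NC(=O)c1csc([N+](=O)[O-])c1)[Se]Cc1ccccc1)c1csc([N+](=O)[O-])c1`, is built on a different core and gives 24400 nM in this assay. The two numbers lie far apart, well beyond the scatter, but since the two compounds share no core, the gap cannot be tied to any single structural change.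

For the measured compounds named here, compound 3 `C[Se]/C(=N\C(=O)c1cc(-c2ccccc2)nc2ccccc12)NC(=O)c1cc(-c2ccccc2)nc2ccccc12` is the one compound still to be tested. It differs from compound 1 in a single place (a group of 2 heavy atoms (1 carbon, 1 selenium; no ring) in place of a group of 2 heavy atoms (1 carbon, 1 sulfur; no ring), on a carbon with a double bond to nitrogen). Going by the values given here, no measured pair shows the effect of this exchange, so any expectation rests on compound 1 alone and on the fact that the rest of the molecule is untouched. The size of the step is expected to be small, within the scatter, with at most a slight lean toward a lower number: the step is expected to be a 1.3-fold lower number from compound 1 to compound 3 (0.12 log units; within the scatter). Compound 3 is therefore estimated at 30 nM in this assay, within a range from 10 nM to 120 nM.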

Compound 3, concentration for 50% growth inhibition: 710 nM
Estimate against measurement, compound 3: 24-fold (1.37 log units) below; the measured number lies above the stated range.
By their numbers in this assay, from the lowest: compound 1; then compound 3; then compound 2.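

In this assay, replacing methylsulfanyl with the selenium-containing group, on a carbon with a double bond to nitrogen, gives an 18-fold higher number from compound 1 to compound 3 (1.25 log units; beyond the scatter). Among the compounds shown here, this is the first comparison here that isolates one change on a shared core, and it shows that this position is sensitive: swapping sulfur for selenium alone moves the number well beyond the scatter, with the sulfur compound giving the stronger inhibition of growth. Nothing at hand explains why this single atom exchange has so large an effect.

For the compounds shown here, the pair gives only one reading at this position, on one core, so it remains open whether the same exchange would raise the number on the core of compound 2 or on any other core. On these data alone, it also remains open how other groups in this place would compare with methylsulfanyl, such as ethylsulfanyl with its longer chain, or an amine, and whether either would keep the number close to that of compound 1 or move it as far as the selenium-containing group does.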